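Urea aryl swap in the shared series: compound 3 outlook

The source may report more compounds than this note shows. Statements on the series, on what has been measured and on what is new or still open speak of the compounds shown alone.

Measured so far:
- compound 1 `COc1cc(Cl)cc(-c2nn(-c3cccc(NC(=O)Nc4cc(C(F)(F)F)cc(C(F)(F)F)c4)c3)cc2-c2ccncc2)c1`: 96%
- compound 2 `COc1cc(Cl)cc(-c2nn(-c3cccc(NC(=O)Nc4ccc(Cl)c(Cl)c4)c3)cc2-c2ccncc2)c1`: 100%

In a functional assay on 786-0 cells (Homo sapiens) for inhibition, read by sulforhodamine B assay, with a stated time of 48 h, tested at 0.01 uM (a higher number here means a weaker effect of the compound at the concentration tested, a lower number a stronger effect), compound 1 gives 96% and compound 2 gives 100%; the two numbers lie within the scatter of each other, so compound 2 stands on a par with compound 1, with neither showing a marked effect at the concentration tested. Compound 3 `COc1cc(Cl)cc(-c2nn(-c3cccc(NC(=O)Nc4cccc(C(F)(F)F)c4)c3)cc2-c2ccncc2)c1` differs from compound 2 by 3-(trifluoromethyl)phenyl in place of 3,4-dichlorophenyl on an amide-type nitrogen. Among the compounds with values here, no step is on hand for this change, and compound 1 to compound 2 shows none beyond the scatter; no step beyond the scatter is expected here either. For compound 3 the estimate is 97% (range 88% to 105%), which means an expected step of a number 3 percentage points lower from compound 2 to compound 3 (within the scatter).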

Compound 3, a percentage reported as activity, at one concentration (the size of the read-out at that concentration, not a potency): 99%
For compound 3 the middle estimate is 2 percentage points below the measured one; the measured number falls inside the stated range.
By their numbers in this assay, from the lowest: compounds 1, 3 and 2 (each within the scatter of the next).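

In this assay, the aryl group on the urea nitrogen now has its first single-place comparisons: 3-(trifluoromethyl)phenyl in place of 3,4-dichlorophenyl gives a number 1 percentage points lower from compound 2 to compound 3 (within the scatter), and hydrogen in place of trifluoromethyl on an aromatic carbon gives a number 3 percentage points higher from compound 1 to compound 3 (within the scatter). At this concentration, neither change separates the compounds, so these three aryl groups cannot be told apart at this position. No measured evidence bears on this result.

Still open, as far as these compounds go, is whether an aryl group carrying a carboxylic acid or an amine, or a longer alkyl chain in place of the aryl ring, would give a number outside this cluster.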